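The source may report more compounds than this note shows. Statements on the series, on what has been measured and on what is new or still open speak of the compounds shown alone.

Measured compounds:
Compound 1, `Cc1ccsc1C(c1ccccn1)N1CCN(c2ncnc3c2cnn3-c2ccccc2)CC1`: in a functional assay on cells (Rhabdomyosarcoma cell, Homo sapiens) for cytotoxicity (on this read-out higher numbers stand for weaker inhibition and lower numbers for stronger inhibition), compound 1 gives > 25000 nM, which is a limit of the assay rather than a number.
Compound 2, `c1ccc(-c2ccc(C(c3ccccc3)N3CCN(c4ncnc5c4cnn5-c4ccccc4)CC3)cc2)cc1`: in this assay compound 2 gives > 25000 nM, again a limit.
Compound 3, `c1ccc(C(c2ccccn2)N2CCN(c3ncnc4c3cnn4-c3ccccc3)CC2)cc1`: in this assay compound 3 gives > 25000 nM, also a limit.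

Within the data shown here, compound 3 therefore stands at the edge of what this assay can report, and the same holds for every value measured so far, since (the limit of > 25000 nM in this assay, at which 3 of the 3 values shown sit). Two measured steps lead into compound 3 and bear on the change considered here: a step that the two limits leave unreadable from compound 1 to compound 3 and a step that the two limits leave unreadable from compound 2 to compound 3. Both run from one limit to another, so neither their size nor their direction can be read.

Compound 4, `c1ccc(C(c2nccs2)N2CCN(c3ncnc4c3cnn4-c3ccccc3)CC2)cc1`, differs from compound 3 by 1,3-thiazol-2-yl in place of pyridin-2-yl on a saturated chain carbon bound to an amine nitrogen in a ring and an aromatic carbon. The changes at this same position that have been measured all left the read-out at the limit, so no step beyond the scatter can be expected in either direction. The step that the limit leaves unreadable from compound 3 to compound 4 is therefore expected to be essentially nil, with compound 4 most likely reported as a limit as well. Compound 4 is estimated at 40000 nM, with a range from 20000 nM to 100000 nM.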

Compound 4, half-maximal inhibitory concentration: > 25000 nM
Compound 4: only a limit was reported; the forecaster's own chance of this, stated with the estimate: 85%; the middle value is on the limit's open side.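

In this assay compound 4 gives > 25000 nM, which is a limit and not a number. Among these compounds, no step from compound 2 or compound 3 to compound 4 can be read. The values shown all stop at the same edge of the read-out: the limit of > 25000 nM in this assay, at which 4 of the 4 values shown sit. The compounds shown leave open how strongly, if at all, any of them inhibits, and whether any group at this place would give a readable value.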